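Small Hydroxy in Place of a Piperidine Amide

The compounds below may be only part of what the source reports. "The series", "measured", "known", "first", "only" and "open" are said of these compounds alone.

Measured so far:
compound 1 `COc1ccc(/C=C\c2cc(OC)c(OC)c(OC)c2)cc1OCc1ccc(CN2C[C@H](O)C[C@@H]2C(=O)O)cc1`: > 10000 nM
compound 2 `COc1ccc(/C=C\c2cc(OC)c(OC)c(OC)c2)cc1OCc1ccc(CN2CC[C@@H](O)C2)cc1`: 6200 nM
compound 3 `COc1ccc(/C=C\c2cc(OC)c(OC)c(OC)c2)cc1OCc1ccc(CN2CCCCC2C(=O)NCCN)cc1`: 4800 nM

The three compounds share one core and differ only in the group carried on a saturated chain carbon bound to an aromatic carbon. In a functional assay on HepG2 cells (Homo sapiens) for antiproliferative activity, read by CCK-8 assay, with a stated time of 48 h (on this read-out lower numbers stand for stronger inhibition and higher numbers for weaker inhibition), compound 1 reaches only the assay limit, > 10000 nM. In this assay compound 2 gives 6200 nM and compound 3 gives 4800 nM. Compound 3 thus has the lowest number of the two that were resolved, yet the gap is a 1.3-fold lower number from compound 2 to compound 3 (0.11 log units; within the scatter), which is within the scatter, so the two cannot be told apart. The step of an at least 2.0-fold lower number from compound 1 to compound 3 (0.31 log units; beyond the scatter) is at least modest, while an at least 1.6-fold lower number from compound 1 to compound 2 (0.20 log units; that floor lies within the scatter) is only a floor.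

Compound 4 `COc1ccc(/C=C\c2cc(OC)c(OC)c(OC)c2)cc1OCc1ccc(CO)cc1` has not been measured. The change is hydroxy in place of 2-((2-aminoethyl)carbamoyl)piperidin-1-yl on a saturated chain carbon bound to an aromatic carbon. For the measured compounds named here, no measured step removes a ring group in favour of a single hydroxy, so the nearest guide is that the three tail groups studied so far moved the read-out little. In this assay compound 4 is therefore expected to land near compound 3, with the step of a 1.1-fold lower number from compound 3 to compound 4 (0.03 log units; within the scatter) taken as no more than scatter. The estimate for compound 4 is 4500 nM, with a range from 1200 nM to 15000 nM.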

Compound 4, half-maximal inhibitory concentration: 2400 nM
Estimate against measurement, compound 4: 1.9-fold (0.27 log units) above; measured number inside the range.
By their numbers in this assay, from the lowest: compounds 4, 3 and 2 (each within the scatter of the next, the first and the last beyond it). At a limit, above all of these: compound 1.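

In this assay, the large 2-((2-aminoethyl)carbamoyl)piperidin-1-yl can be replaced by a single hydroxy with no loss: a 2.0-fold lower number from compound 3 to compound 4 (0.30 log units; within the scatter), so on this saturated chain carbon the ring, its amide and its primary amine are not needed to keep the read-out at this level. For the compounds shown here, the same hydroxy in place of 3-hydroxypyrrolidin-1-yl gives a 2.6-fold lower number from compound 2 to compound 4 (0.41 log units; beyond the scatter), the first step between two resolved numbers in this set that lies beyond the scatter, though it remains modest in size. The step of an at least 4.1-fold lower number from compound 1 to compound 4 (0.61 log units; beyond the scatter) is only a floor, and what sets it is this: the limit of > 10000 nM in this assay, at which 1 of the 4 values shown sits.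

The compounds shown do not tell whether the hydroxy oxygen itself matters or whether shedding the ring tail is enough, and a methyl, a methoxy or a primary amine on the same carbon would separate those two readings. They also leave open how an open-chain tertiary amine such as dimethylamino, or a carboxylic acid without the ring of compound 1, would compare with compound 4.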